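The source may report more compounds than this note shows. Statements on the series, on what has been measured and on what is new or still open speak of the compounds shown alone.

Of the compounds shown here, three built on one shared core have been measured in a functional assay on A-375 cells (Homo sapiens) for antiproliferative activity, read by MTT assay, with a stated time of 24 h, tested at 33.33 ug/mL; a lower number here means a weaker effect, a higher number a stronger effect of the compound at the concentration tested. Compound 3 `Cc1c(C(=O)Nc2c(F)cc(-c3cccc(F)c3)cc2F)nc2ccc(C(F)(F)F)cc2c1O` gives 61.3%, the highest of the three numbers; compound 1 `Cc1c(C(=O)Nc2c(F)cc(-c3cccc(F)c3)cc2F)nc2ccc(F)cc2c1O` gives 28.8%, and compound 2 `Cc1c(C(=O)Nc2c(F)cc(-c3cccc(F)c3)cc2F)nc2ccc(OC(F)(F)F)cc2c1O` gives 12.3%. The measured steps, a number 32.5 percentage points higher from compound 1 to compound 3 (beyond the scatter) and a number 49 percentage points higher from compound 2 to compound 3 (beyond the scatter), all concern a group on another part of the core. Compound 4 `Cc1c(C(=O)Nc2c(F)cc(-c3cccc(F)c3)cc2F)nc2ccc(C(F)(F)F)cc2c1C(=O)O` differs from compound 3 elsewhere: carboxy in place of hydroxy on an aromatic carbon. Among the compounds with values here, no measured step touches the hydroxy, so the data give no guide to the size or direction of this step, and a wide range is the honest answer. Close to compound 3 but with that wide range, the expected value for compound 4 is 50%, between 20% and 75%. This estimate means an expected step of a number 11.3 percentage points lower from compound 3 to compound 4 (beyond the scatter).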

Compound 4, a percentage reported as inhibition, at one concentration (the size of the read-out at that concentration, not a potency): 51%
For compound 4 the middle estimate is 1 percentage points below the measured one; the range from low to high includes it.
By their numbers in this assay, from the lowest: compound 2; then compound 1; then compound 4; then compound 3.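

Within the data shown here, this is the first measured change at the hydroxy position: in this assay, carboxy in place of hydroxy gives a number 10.3 percentage points lower from compound 3 to compound 4 (beyond the scatter), a modest step. The position therefore accepts this larger group with a real but limited loss, and much of the read-out remains. No measurement shown explains the drop.

As far as these compounds go, whether an amine or a methoxy group here would raise or lower the number stays open. So does whether the carboxy step would keep its size with fluoro or trifluoromethoxy in place of trifluoromethyl.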